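The source may hold more compounds than are shown below. What is called first, only, known or untested is meant among the compounds shown, and "the series" means these compounds.

Working notes on the series. Compound 1 `CC(C)(C)c1nnc(-c2ccc(N3CCC(Oc4ccccc4C(F)(F)F)CC3)nn2)s1` and compound 2 `CC(C)(C)c1nnc(-c2ccc(N3CCC(Oc4ccccc4C(F)(F)F)CC3)nn2)o1` share one core and differ only in the five-membered ring that carries the tert-butyl group. In an assay on microsomes from liver for inhibition of acyl-CoA desaturase 1 (Rattus norvegicus) (on this read-out lower numbers stand for stronger inhibition and higher numbers for weaker inhibition), compound 1 gives 710 nM, and in the same assay compound 2 gives 980 nM. For the measured compounds named here, the step of a 1.4-fold higher number from compound 1 to compound 2 (0.14 log units; within the scatter) is the only measured step in hand. Compound 2 thus carries the highest of the two numbers, with compound 1 the nearest, and since that gap lies within the scatter no order between the two can be read.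

Compound 3 `OCc1nnc(-c2ccc(N3CCC(Oc4ccccc4C(F)(F)F)CC3)nn2)o1` keeps the core of compound 2 and alters the group on the five-membered ring: hydroxymethyl in place of tert-butyl on an aromatic carbon. Going by the values given here, no measured step bears on this exchange; the single step of a 1.4-fold higher number from compound 1 to compound 2 (0.14 log units; within the scatter) swaps the ring itself while leaving the tert-butyl group in place, so it offers no guide to replacing that group. As far as these compounds go, the exchange is untested and is large in what it removes and adds, so a step toward weaker inhibition, beyond the scatter, is expected, a 3.1-fold higher number from compound 2 to compound 3 (0.49 log units; beyond the scatter), with wide uncertainty. Compound 3 is therefore estimated to give 3000 nM, in the range 800 nM to 12000 nM.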

Compound 3, half-maximal inhibitory concentration: 2.9 nM
Estimate against measurement, compound 3: 1000-fold (3.01 log units) above; the measured number lies below the stated range.
By their numbers in this assay, from the lowest: compound 3; then compounds 1 and 2 (each within the scatter of the next).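

In this assay, the group on the aromatic carbon of the five-membered ring emerges as a strong determinant of the read-out: hydroxymethyl in place of tert-butyl gives a 340-fold lower number from compound 2 to compound 3 (2.53 log units; beyond the scatter), whereas the exchange of the ring alone stayed within the scatter. The wider exchange, 5-(hydroxymethyl)-1,3,4-oxadiazol-2-yl in place of 5-(tert-butyl)-1,3,4-thiadiazol-2-yl, gives a 240-fold lower number from compound 1 to compound 3 (2.39 log units; beyond the scatter), which places compound 3 as the strongest inhibitor of the three, with both of its steps beyond the scatter. No measured evidence on the origin of this large step is in hand.

The compounds shown leave open which part of the exchange matters, since the smaller group and the hydroxyl enter together; a methyl group, a methoxymethyl group or an aminomethyl group at this position would help to separate the two. They also leave open whether hydroxymethyl behaves the same way on the 1,3,4-thiadiazole ring of compound 1, and whether a longer chain such as hydroxyethyl or a carboxylic acid keeps a number this low.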